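The source may hold more compounds than are shown below. What is called first, only, known or untested is meant among the compounds shown, and "the series" means these compounds.

Of the compounds shown here, three built on one shared core have been tested in an ADME assay on HPC cells (Homo sapiens) for cytotoxicity, with a stated time of 48 h; on this read-out lower numbers stand for higher toxicity in this test and higher numbers for lower toxicity in this test. Compound 1 `Cc1c(C(=O)/C=C/c2cccc([N+](=O)[O-])c2)[n+]([O-])c2ccccc2[n+]1[O-]` gives 46000 nM in this assay. Compound 2 `COc1ccc(/C=C/C(=O)c2c(C)[n+]([O-])c3ccccc3[n+]2[O-])cc1OC` gives 142000 nM. Compound 3 `Cc1c(C(=O)/C=C/c2ccc(Cl)cc2)[n+]([O-])c2ccccc2[n+]1[O-]` gives 21000 nM, the lowest of the three numbers: compound 1 sits above it by a gap beyond the scatter, and compound 2 sits further above, also beyond the scatter. Compound 4 `Cc1c(C(=O)/C=C/c2ccc(F)cc2)[n+]([O-])c2ccccc2[n+]1[O-]` differs from compound 3 in a single place: fluoro in place of chloro on an aromatic carbon, which is fluoro in place of chloro on an aromatic carbon. Among the compounds with values here, no measured pair shows this exact change, so nothing here tells how large its effect is. A small upward step, a 1.4-fold higher number from compound 3 to compound 4 (0.15 log units; within the scatter), is expected, close to or within the scatter. Compound 4 is therefore estimated at 30000 nM, with a likely range from 12000 nM to 75000 nM.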

Compound 4, half-maximal cytotoxic concentration: 48000 nM
Beside the measured number, compound 4's estimate is 1.6-fold (0.20 log units) below it; low and high end bracket the measured number.
By their numbers in this assay, from the lowest: compound 3; then compounds 1 and 4 (each within the scatter of the next); then compound 2.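

In this assay, within the data shown here, this is the first single-place change on the shared core, so the swap now has a size: fluoro in place of chloro on an aromatic carbon, para to a large group, gives a 2.3-fold higher number from compound 3 to compound 4 (0.36 log units; beyond the scatter) as a modest step. This position therefore responds to which of these two halogens it carries. Nothing measured here explains the shift. On these data alone, how an amine or a carboxylic acid would fare at this position stays open, as does whether the same swap gives a similar step on the other compounds.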